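Replacing the Trifluoromethylphenyl Group of Compound 1

This account rests on a few compounds, and the source may have more. Where it says the series, first, only, none or still open, it means among the compounds named here.

Measured compounds:
compound 1, `COc1cc(C2=NN(C(C)=O)C(c3ccccc3C(F)(F)F)O2)cc(OC)c1OC`: 15.2%
compound 2, `COc1cc(C(=O)N/N=C/c2cccc(C(F)(F)F)c2)cc(OC)c1OC`: 79.8%

In a functional assay on PC-3 cells (Homo sapiens) for antiproliferative activity, read by MTT assay, tested at 5 uM (a higher number here means a stronger effect of the compound at the concentration tested, a lower number a weaker effect), compound 1 gives 15.2%, the lowest of the two numbers. Compound 2, built on a different core, gives 79.8%, and the gap between these two values lies well beyond the usual scatter. Since the two compounds differ in more than one place, their values say nothing about any single change.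

Compound 3, `COc1cc(C2=NN(C(C)=O)C(c3cccc(OC)c3OC)O2)cc(OC)c1OC`, keeps the core of compound 1 and differs from it in one place: 2,3-dimethoxyphenyl in place of 2-(trifluoromethyl)phenyl on a saturated ring carbon. Going by the values given here, no pair of measured compounds shows this exchange, so there is no measured step to lean on. The step from compound 1 to compound 3 is expected to be small, a number 9.8 percentage points higher from compound 1 to compound 3 (within the scatter), most likely a modest rise or none beyond the scatter. Compound 3 is therefore estimated at 25%, with a range from 5% to 55%.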

Compound 3, a percentage reported as inhibition, at one concentration (the size of the read-out at that concentration, not a potency): 58.2%
The estimate for compound 3 lay 33.2 percentage points below the measured number; the whole stated range lies below it.
By their numbers in this assay, from the lowest: compound 1; then compound 3; then compound 2.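

In this assay, the group on the saturated ring carbon of the shared core proves able to change the read-out strongly: 2,3-dimethoxyphenyl in place of 2-(trifluoromethyl)phenyl gives a number 43 percentage points higher from compound 1 to compound 3 (beyond the scatter). Going by these compounds alone, this is the first comparison here in which only one place differs, so the size of the change can be tied to this exchange, which the earlier pair of compounds could not do. No measurement bearing on why the number rises accompanies this step.

The exchange replaces the whole group at once, so the compounds shown cannot separate the loss of the trifluoromethyl group from the gain of the two methoxy groups. Going by these compounds, how an unsubstituted phenyl ring, a single methoxy group or an amine on the ring would read at this position remains open.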